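Swapping a Ring Methyl for Methylsulfanyl on the Shared Core

A few compounds are considered here, and "the series" means these few. Any claim that something is new, unique, unknown or untested is made for them only; others in the source may bear on it.

Compound 1 `COc1cc(C)nc2n/c(=N/C(=O)c3c(-c4ccc(Cl)cc4Cl)noc3C)sn12` gives 80.4% in a functional assay on the whole organism for inhibition, with Chenopodium ficifolium as the target, with a stated time of 72 h, tested at 100 mg/L; on this read-out higher numbers stand for more inhibition of growth at the one concentration tested and lower numbers for less inhibition of growth. Compound 2 `COc1cc(Cl)nc(NC(=S)NC(=O)c2c(-c3ccc(Cl)cc3Cl)noc2C)n1` gives 53.2% in this assay. Compound 3 `CSc1cc(C)nc2n/c(=N/C(=O)c3c(-c4ccc(Cl)cc4Cl)noc3C)sn12` gives 75.2% in this assay.

Of the three numbers, compound 1 stands at the top, but its nearest neighbour, compound 3, sits within the usual scatter of it, so the two cannot be told apart on this read-out; only compound 2, with its open-chain thiourea in place of the fused core, lies clearly lower.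

Compound 4 `COc1cc(SC)nc2n/c(=N/C(=O)c3c(-c4ccc(Cl)cc4Cl)noc3C)sn12` has not yet been measured. It differs from compound 1 in one place: methylsulfanyl in place of methyl on an aromatic carbon. For the measured compounds named here, one measured step bears on this change. Going from compound 1 to compound 3, a methylsulfanyl group replaces a methoxy group on the same six-membered ring of the core, and that step gave a number 5.2 percentage points lower from compound 1 to compound 3 (within the scatter). Placing a methylsulfanyl group onto this ring therefore left the read-out essentially unchanged in the one case where it was tried, although that case exchanged it for methoxy rather than for methyl.

Compound 4 is accordingly expected to stay close to compound 1, with a step of about a number 4.4 percentage points lower from compound 1 to compound 4 (within the scatter). The estimate for compound 4 in this assay is 76%, with a range from 60% to 88%.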

Compound 4, percent growth inhibition at one concentration: 68.3%
For compound 4 the middle estimate is 7.7 percentage points above the measured one; measured number inside the range.
By their numbers in this assay, from the lowest: compound 2; then compounds 4, 3 and 1 (each within the scatter of the next, the first and the last beyond it).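

In this assay the swap of methyl for methylsulfanyl gave a number 12.1 percentage points lower from compound 1 to compound 4 (beyond the scatter) and so moved the read-out by a modest but real amount, which shows that this position, on an aromatic carbon next to the ring nitrogen, is not indifferent to what it carries. For the compounds shown here, the only earlier step on this ring, methylsulfanyl in place of methoxy, gave a number 5.2 percentage points lower from compound 1 to compound 3 (within the scatter) and stayed inside the scatter, so the earlier compounds alone left it possible that methylsulfanyl could enter the ring with no visible cost, and the new step shows that this does not hold for every place and every group it replaces. Nothing measured on these compounds accounts for the loss of growth inhibition seen at this position.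

The compounds shown leave open whether the loss goes with the sulfur of the entering group or with any replacement of methyl, as this is the only replacement at this position among them. Going by these compounds, an amine or an ethyl chain on the same carbon would help separate these two readings, and whether either would hold the read-out near that of compound 1 remains unknown.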